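Aryl exchange at the ethenyl chain end: working notes

The source may report more compounds than this note shows. Statements on the series, on what has been measured and on what is new or still open speak of the compounds shown alone.

Values in a functional assay on A549 cells (Homo sapiens) for cytotoxicity, read by MTT assay, with a stated time of 72 h; a lower number here means a stronger inhibitor, a higher number a weaker inhibitor:
- compound 1 `COc1ccc(/C=C/C(=O)Nc2cc3c(Nc4ccc(F)c(Cl)c4)ncnc3cc2O[C@H]2CCOC2)c(OC)c1`: 9350 nM
- compound 2 `O=C(/C=C/c1ccccc1[N+](=O)[O-])Nc1cc2c(Nc3ccc(F)c(Cl)c3)ncnc2cc1O[C@H]1CCOC1`: 8820 nM
- compound 3 `O=C(/C=C/c1ccc(F)cc1Cl)Nc1cc2c(Nc3ccc(F)c(Cl)c3)ncnc2cc1O[C@H]1CCOC1`: 5190 nM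

Compound 3 is not separated from the other two: a 1.8-fold lower number from compound 1 to compound 3 (0.26 log units; within the scatter) and a 1.7-fold lower number from compound 2 to compound 3 (0.23 log units; within the scatter) both lie within the scatter. The next change, to compound 4 `O=C(/C=C/c1ccc(Br)cc1)Nc1cc2c(Nc3ccc(F)c(Cl)c3)ncnc2cc1O[C@H]1CCOC1`, is 4-bromophenyl in place of 2-chloro-4-fluorophenyl on a double-bonded chain carbon bound to a double-bonded chain carbon. It puts 4-bromophenyl in place of 2-chloro-4-fluorophenyl on a double-bonded chain carbon bound to a double-bonded chain carbon. The measured exchanges at this place bear on it, and a 1.1-fold lower number from compound 1 to compound 2 (0.03 log units; within the scatter) also stays within the scatter. Among the measured compounds shown here, none of the measured compounds carries 4-bromophenyl. No step beyond the scatter is therefore expected in this assay. The expected step is a 1.3-fold higher number from compound 3 to compound 4 (0.10 log units; within the scatter). Compound 4 is estimated at 6500 nM, with an expected range from 2800 nM to 14000 nM.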

Compound 4, half-maximal inhibitory concentration: 35300 nM
Compound 4: the middle estimate sits 5.4-fold (0.73 log units) below what was measured; measured number outside the range, above it.
By their numbers in this assay, from the lowest: compounds 3, 2 and 1 (each within the scatter of the next); then compound 4.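

In this assay this position is no longer flat: an aryl exchange here now moves the number beyond the scatter (a 6.8-fold higher number from compound 3 to compound 4 (0.83 log units; beyond the scatter)), (a 4.0-fold higher number from compound 2 to compound 4 (0.60 log units; beyond the scatter)) and (a 3.8-fold higher number from compound 1 to compound 4 (0.58 log units; beyond the scatter)). Compound 4 alone separates, on the weaker side, while compounds 1, 2 and 3 stay within the scatter of each other. Nothing measured here accounts for this step.

Open, from the compounds shown here alone, is whether unsubstituted phenyl would fall with compound 4 or with compounds 1, 2 and 3. Also open, going by these compounds, is how an aryl group bearing an amine or a carboxylic acid would read at this place.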